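Dropping the Methoxy Group: What to Expect for Compound 3

This account rests on a few compounds, and the source may have more. Where it says the series, first, only, none or still open, it means among the compounds named here.

Measured so far:
compound 1, `COC(=O)c1ccc(Cl)cc1OC(=O)COc1cc(O)c2c(=O)cc(-c3ccccc3)oc2c1`: 12400 nM
compound 2, `COC(=O)c1cccc(OC)c1OC(=O)COc1cc(O)c2c(=O)cc(-c3ccccc3)oc2c1`: 36800 nM

Both were tested in a functional assay on cells (T-cell, Mus musculus, strain BALB/c) for inhibition, read by MTT assay, with a stated time of 72 h; on this read-out lower numbers stand for stronger inhibition and higher numbers for weaker inhibition. Compound 2 stands at the highest of the two numbers; compound 1 lies lower than compound 2 by a margin beyond the usual scatter. Compound 3, `COC(=O)c1ccccc1OC(=O)COc1cc(O)c2c(=O)cc(-c3ccccc3)oc2c1`, is still unmeasured. It differs from compound 2 in a single place: hydrogen in place of methoxy on an aromatic carbon. Among the compounds with values here, no measured pair mirrors this change, so the direction rests on the structural change alone. The expected step is a 1.5-fold lower number from compound 2 to compound 3 (0.17 log units; within the scatter), a small move toward a lower number, likely within the scatter. Compound 3 is estimated at 25000 nM, with a range from 8000 nM to 80000 nM.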

Compound 3, half-maximal inhibitory concentration: 28500 nM
Beside the measured number, compound 3's estimate is 1.1-fold (0.06 log units) below it; measured number inside the range.
By their numbers in this assay, from the lowest: compound 1; then compounds 3 and 2 (each within the scatter of the next).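

In this assay, hydrogen in place of methoxy on this aromatic carbon gives a 1.3-fold lower number from compound 2 to compound 3 (0.11 log units; within the scatter), so the methoxy group can go without a change that stands out from the scatter. Hydrogen in place of chloro on an aromatic carbon gives a 2.3-fold higher number from compound 1 to compound 3 (0.36 log units; beyond the scatter), a modest step, and so compound 1 is the one that stands apart from hydrogen here. Nothing at hand explains either step. The compounds shown leave open how an amine or a carboxylic acid on the methoxy-bearing carbon would read. They also leave open whether a longer chain there would differ from methoxy.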